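The source may hold more compounds than are shown below. What is called first, only, known or untested is meant among the compounds shown, and "the series" means these compounds.

Measured compounds:
compound 1 `Nc1ccccc1NC(=O)c1ccc(CSC(=S)N2CCN(Cc3ccccn3)CC2)cc1` — 14.2%
compound 2 `CN(Cc1cccnc1)C(=S)SCc1ccc(C(=O)Nc2ccccc2N)cc1` — 16.4%

The study covers two measured compounds and one that has not yet been tested. In a functional assay on HeLa cells (Homo sapiens) for antiproliferative activity, read by CCK-8 assay, with a stated time of 72 h, tested at 2 uM (on this read-out higher numbers stand for a stronger effect at the one concentration tested and lower numbers for a weaker effect), compound 1 gives 14.2%. Among the measured compounds shown here, compound 2, the only other measured compound, gives 16.4% in this assay. The two values lie within the usual scatter of each other, so compound 1 cannot be set apart from compound 2 on these numbers; both show only a modest effect at the one concentration tested.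

Compound 3 `Nc1ccccc1NC(=O)c1ccc(CSC(=S)N2CCN(c3ccccc3)CC2)cc1` has not been measured in this assay. It differs from compound 1 in one place: phenyl in place of (pyridin-2-yl)methyl on an amine nitrogen in a ring. For the measured compounds named here, no pair of measured compounds separated by a single change is available to show how a change of this kind shifts the read-out, so the expectation for compound 3 rests on the weak effect shared by compound 1 and compound 2. A step of a number 1.8 percentage points higher from compound 1 to compound 3 (within the scatter) is expected, that is, no change beyond the scatter. Compound 3 is therefore estimated at 16%, with a range from 5% to 30%.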

Compound 3, a percentage reported as inhibition, at one concentration (the size of the read-out at that concentration, not a potency): 62.2%
Compound 3: the middle estimate sits 46.2 percentage points below what was measured; measured number above the stated range.
By their numbers in this assay, from the lowest: compounds 1 and 2 (each within the scatter of the next); then compound 3.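

Phenyl in place of (pyridin-2-yl)methyl on an amine nitrogen in a ring gives, in this assay, a step of a number 48 percentage points higher from compound 1 to compound 3 (beyond the scatter) and so separates two compounds by this single change. Among the compounds shown here, the earlier compounds offered no such pair, and this is the first sign that the group on this nitrogen can move the read-out beyond the scatter. Nothing available here accounts for the size of the step.

The change removes the ring nitrogen and the methyl link to the aromatic ring together, so the compounds shown do not tell these two differences apart. As far as these compounds go, how a benzyl group or a pyridin-2-yl group on the same nitrogen would read remains open, as does whether substituents on the phenyl ring would keep the effect.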